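The source may report more compounds than this note shows. Statements on the series, on what has been measured and on what is new or still open speak of the compounds shown alone.

Measured compounds so far:

- compound 1, `O=C(O)Cn1c(SCCCc2ccccc2)nc2ccccc21`: 475 nM
- compound 2, `COc1cccc(CSc2nc3ccccc3n2CC(=O)O)c1`: 72 nM
- compound 3, `COc1ccc(C)cc1CSc1nc2ccccc2n1CC(=O)O`: 1200 nM

All three share the same core and differ only in the group carried on the sulfur. In an assay on HEK293 cells for displacement of a labelled ligand from prostaglandin D2 receptor 2 (Homo sapiens) (on this read-out higher numbers stand for weaker inhibition and lower numbers for stronger inhibition), compound 2 gives the lowest number of the three and is the most potent of the measured set; compound 1 gives 475 nM and compound 3 gives 1200 nM, both steps away from compound 2 beyond the usual scatter. No pair among these three differs in a single place, so no isolated step has been measured.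

Compound 4, `CC(=O)c1cccc(CSc2nc3ccccc3n2CC(=O)O)c1`, is the next point. Relative to compound 2 the change is acetyl in place of methoxy on an aromatic carbon. Among the measured compounds shown here, the measured set offers no step of this kind, so the direction is open; a change at the same place on the same ring, without any other edit, is expected to leave the number within a modest step of compound 2, with a slight lean toward a higher number. The estimate for compound 4 in this assay is 150 nM, with a range from 40 nM to 600 nM. The expected step from compound 2 to compound 4 is a 2.1-fold higher number from compound 2 to compound 4 (0.32 log units; beyond the scatter).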

Compound 4, half-maximal inhibitory concentration: 230 nM
For compound 4 the middle estimate is 1.5-fold (0.19 log units) below the measured one; the range from low to high includes it.
By their numbers in this assay, from the lowest: compound 2; then compound 4; then compound 1; then compound 3.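

Acetyl in place of methoxy on an aromatic carbon, meta to a large group, gives a 3.2-fold higher number from compound 2 to compound 4 (0.50 log units; beyond the scatter) in this assay and is the first step in the series that isolates a single place. The number at this position therefore responds to the identity of the group, even though both groups carry one hydrogen-bond acceptor and no net charge, so those two counts do not by themselves fix the number. No measurement on hand accounts for the size or direction of this step.

On these data alone, whether an amine, a carboxylic acid or a longer alkoxy chain at this same place would give a lower or a higher number remains open. Also open, as far as these compounds go, is how methoxy or acetyl would read on the other carbons of this ring.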